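The source may hold more compounds than are shown below. What is called first, only, known or untested is meant among the compounds shown, and "the series" means these compounds.

Compound 3 `Cn1cc(-c2cccc(Cl)c2)c2cc(C(=O)NCc3ccc(C(=O)Nc4ccccc4N)cc3)[nH]c2c1=O` gives 190 nM in a functional assay on MV4-11 cells (Homo sapiens) for antiproliferative activity, read by CCK-8 assay, with a stated time of 72 h (a higher number here means a weaker inhibitor, a lower number a stronger inhibitor), the lowest of the three numbers recorded. Compound 1 `COc1cccc(-c2cn(C)c(=O)c3[nH]c(C(=O)NCc4ccc(C(=O)Nc5ccccc5N)cc4)cc23)c1` gives 250 nM and compound 2 `Cn1cc(-c2ccccc2Oc2ccccc2)c2cc(C(=O)NCCCC(=O)NO)[nH]c2c1=O` gives 380 nM, and both sit within the scatter of compound 3. Compound 4 `COc1ccccc1-c1cn(C)c(=O)c2[nH]c(C(=O)NCc3ccc(C(=O)Nc4ccccc4N)cc3)cc12` differs from compound 3 by 2-methoxyphenyl in place of 3-chlorophenyl on an aromatic carbon. Within the data shown here, the one measured step that bears on this is a 1.3-fold lower number from compound 1 to compound 3 (0.12 log units; within the scatter), in which chloro replaced methoxy and the number hardly moved. Among the measured compounds shown here, no measured step shows the effect of 2-methoxyphenyl in place of 3-chlorophenyl, so compound 4 is expected to stay close to compound 3, with the step of a 1.3-fold higher number from compound 3 to compound 4 (0.12 log units; within the scatter) expected to fall within the scatter. Compound 4 is estimated at 250 nM, with a range from 100 nM to 650 nM.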

Compound 4, half-maximal inhibitory concentration: 200 nM
Compound 4: middle estimate off by 1.3-fold (0.10 log units), on the high side, and the stated range covers the measured number.
By their numbers in this assay, from the lowest: compounds 3, 4, 1 and 2 (each within the scatter of the next).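

In this assay, the group on this aromatic carbon tolerated a change of both substituent and its place on the ring, with 2-methoxyphenyl in place of 3-chlorophenyl giving a 1.1-fold higher number from compound 3 to compound 4 (0.02 log units; within the scatter). Moving the methoxy alone, with 2-methoxyphenyl in place of 3-methoxyphenyl, gave a 1.3-fold lower number from compound 1 to compound 4 (0.10 log units; within the scatter), so a shift of position now joins the earlier exchange of chloro for methoxy, and neither step leaves the scatter. Nothing available accounts for this flat response. Still open, on these data alone, is whether an amine or a carboxylic acid on this phenyl ring would leave the number equally unmoved.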